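Moving the Ring Nitrogen on a Carbonyl-Linked Pyridine

This account rests on a few compounds, and the source may have more. Where it says the series, first, only, none or still open, it means among the compounds named here.

Of the compounds shown here, two have been measured in an assay on HEK293 cells for agonist activity at Toll-like receptor 8 (Homo sapiens), read by a luciferase reporter, with a stated time of 6 h; on this read-out higher numbers stand for an effect only at larger amounts of compound and lower numbers for an effect already at smaller amounts. Compound 1 `CCCCNc1nc(N)nc2c1CN(Cc1ccncc1)CC2` gives 0.29 uM in this assay. Compound 2 `CCCCNc1nc(N)nc2c1CN(C(=O)c1ccccn1)CC2` gives 2.9 uM in this assay, the highest of the two numbers; the step of a 10-fold higher number from compound 1 to compound 2 (1.00 log units; beyond the scatter) is beyond the scatter and combines two alterations at once, a change of linker and a change of ring attachment point.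

Compound 3 `CCCCNc1nc(N)nc2c1CN(C(=O)c1ccncc1)CC2` differs from compound 2 only in one respect: pyridin-4-yl in place of pyridin-2-yl on a carbonyl carbon. Among the measured compounds shown here, no measured step isolates this change alone, since the single known step also swaps the linking group, so there is no direct guide to its size or direction. With that gap, the expected step of a 1.2-fold lower number from compound 2 to compound 3 (0.06 log units; within the scatter) is small, with a wide margin. Compound 3 is therefore estimated to give 2.5 uM in this assay, between 0.7 uM and 8 uM.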

Compound 3, minimum effective concentration: > 25 uM
Compound 3 ended at the assay's limit; the forecaster's own chance of this, stated with the estimate: 10%; middle value at least 10-fold (1.00 log units) away from the limit.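

Swapping pyridin-2-yl for pyridin-4-yl on the carbonyl carbon gives an at least 8.6-fold higher number from compound 2 to compound 3 (0.93 log units; beyond the scatter), so the attachment point of the ring alone matters at this position, even though the two groups have the same atoms and the same counts. With pyridin-4-yl now on both sides, the linker can also be read on its own: (pyridin-4-yl)carbonyl in place of (pyridin-4-yl)methyl gives an at least 86-fold higher number from compound 1 to compound 3 (1.93 log units; beyond the scatter). Compound 3 stands at a limit of the assay and not at a number: the limit of > 25 uM in this assay, at which 1 of the 3 values shown sits.

The compounds shown do not tell how pyridin-3-yl would read on the same carbonyl carbon. They also leave open whether the order of pyridin-2-yl and pyridin-4-yl holds on a methyl linker, which a (pyridin-2-yl)methyl group would test.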